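Swapping the anilide aryl group on a bis-nitrobenzylidene core

This account rests on a few compounds, and the source may have more. Where it says the series, first, only, none or still open, it means among the compounds named here.

Compound 2 `O=C(/C=C/C(=O)N1C/C(=C\c2ccc([N+](=O)[O-])cc2)C(=O)/C(=C/c2ccc([N+](=O)[O-])cc2)C1)Nc1ccc(Cl)c(Cl)c1` holds the lower of the two numbers recorded in a functional assay on Molt4/C8 cells (Homo sapiens) for cytotoxicity (on this read-out lower numbers stand for stronger inhibition and higher numbers for weaker inhibition), where compound 2 gives 600 nM; compound 1 `O=C(/C=C/C(=O)N1C/C(=C\c2ccccc2)C(=O)/C(=C/c2ccccc2)C1)Nc1ccc([N+](=O)[O-])cc1` gives 31000 nM in this assay. Compound 3 `O=C(/C=C/C(=O)N1C/C(=C\c2ccc([N+](=O)[O-])cc2)C(=O)/C(=C/c2ccc([N+](=O)[O-])cc2)C1)Nc1ccc([N+](=O)[O-])cc1` differs from compound 2 by 4-nitrophenyl in place of 3,4-dichlorophenyl on an amide-type nitrogen. For the measured compounds named here, no pair of measured compounds isolates this change, and compound 1 differs from compound 3 in a second place as well, so the direction is uncertain. A moderate weakening is expected, a 3.3-fold higher number from compound 2 to compound 3 (0.52 log units; beyond the scatter), and compound 3 is estimated at 2000 nM in this assay, within a range of 400 nM to 12000 nM.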

Compound 3, half-maximal inhibitory concentration: 430 nM
The estimate for compound 3 lay 4.7-fold (0.67 log units) above the measured number, within the range that was stated.
By their numbers in this assay, from the lowest: compounds 3 and 2 (each within the scatter of the next); then compound 1.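

In this assay, 4-nitrophenyl in place of 3,4-dichlorophenyl on the amide-type nitrogen gives a 1.4-fold lower number from compound 2 to compound 3 (0.14 log units; within the scatter). For the compounds shown here, this is the first comparison that isolates this position, and on this core the two aryl groups cannot be told apart. Nothing available explains why they read alike. As far as these compounds go, whether an unsubstituted phenyl, a 4-aminophenyl or a 4-carboxyphenyl group would read the same on this nitrogen remains open. So does whether the two groups would also match on the core of compound 1.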